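Methoxycarbonyl for tert-Butyl: A Cytotoxicity Outlook

The compounds below may be only part of what the source reports. "The series", "measured", "known", "first", "only" and "open" are said of these compounds alone.

The measured compounds in an ADME assay on HCT-116 cells (Homo sapiens) for cytotoxicity, read by CellTiter-Glo, with a stated time of 72 h; a lower number here means a stronger inhibitor, a higher number a weaker inhibitor:
- compound 1 `CC1CCN(C2CCN(S(=O)(=O)c3ccc(C(C)(C)C)cc3)CC2)CC1`, reported only as a limit, > 5000 nM
- compound 2 `CC1CCN(C2CCN(S(=O)(=O)c3cccnc3Cl)CC2)CC1`, reported only as a limit, > 10000 nM
- compound 3 `Cc1ccc(-c2cccc(S(=O)(=O)N3CCC(N4CCC(C)CC4)CC3)c2)cc1`, reported only as a limit, > 5000 nM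

Compound 1 therefore has no number of its own in this assay, only a limit, and it sits where two of the three values sit, at the limit of > 5000 nM in this assay, at which 2 of the 3 values shown sit, while the remaining value sits at the limit of > 10000 nM in this assay, at which 1 of the 3 values shown sits. No pair among these three differs in a single place, so no measured step is available to lean on.

Compound 4 `COC(=O)c1ccc(S(=O)(=O)N2CCC(N3CCC(C)CC3)CC2)cc1` takes the step from compound 1 described by methoxycarbonyl in place of tert-butyl on an aromatic carbon. With every value shown being a limit, the step from compound 1 to compound 4 in this assay is expected to be none beyond the scatter, that is a step that the limit leaves unreadable from compound 1 to compound 4. Compound 4 is accordingly expected to give about 10000 nM, within 4000 nM to 30000 nM, and most likely to be reported only as a limit again.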

Compound 4, half-maximal inhibitory concentration: > 5000 nM
Compound 4: no number, only a limit; the forecaster's own chance of this, stated with the estimate: 85%; the middle value lies beyond the limit too.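

In this assay compound 4 is reported only as a limit, > 5000 nM. Among these compounds, compound 1 is likewise a limit, > 5000 nM, and no step between the two can be read. The compounds shown leave open whether methoxycarbonyl in place of tert-butyl changes cytotoxicity at all.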